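A few compounds are considered here, and "the series" means these few. Any claim that something is new, unique, unknown or untested is made for them only; others in the source may bear on it.

In an ADME assay for permeability, using PAMPA, at pH 7.4 (a lower number here means that the compound crosses the layer more slowly, a higher number that the compound crosses the layer faster), compound 2 `C[C@@H]1CN(c2cccc3c2C[C@H](CN(C)[C@H]2CCCc4cccnc42)NC3)C[C@H](C)N1` gives 39 nm/s, the lower of the two numbers in hand, while compound 1 `CN(C[C@H]1Cc2c(cccc2N2CCN(C3COC3)CC2)CN1)[C@H]1CCCc2cccnc21` gives 725 nm/s. The next step leads to compound 3 `CN(C[C@H]1Cc2c(cccc2N2CCN(C3CC3)CC2)CN1)[C@H]1CCCc2cccnc21`, not yet measured: 4-cyclopropylpiperazin-1-yl in place of 3,5-dimethylpiperazin-1-yl on an aromatic carbon. In words, 4-cyclopropylpiperazin-1-yl stands in place of 3,5-dimethylpiperazin-1-yl on an aromatic carbon, and the core stays the same.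

Within the data shown here, one measured step bears on this change: a 19-fold lower number from compound 1 to compound 2 (1.27 log units; beyond the scatter). It is large and beyond the scatter, and it puts 3,5-dimethylpiperazin-1-yl in place of 4-(oxetan-3-yl)piperazin-1-yl. Compound 3 carries a 4-substituted piperazin-1-yl, as does compound 1 at 725 nm/s, so much of that step is expected to return in the opposite direction. Among the measured compounds shown here, the support is thin, since it is a single step and no measured compound in this set carries the cyclopropyl group. A large step to a higher number in this assay is expected, of a 10-fold higher number from compound 2 to compound 3 (1.01 log units; beyond the scatter). For compound 3 the estimate is 400 nm/s, with an expected range of 150 nm/s to 900 nm/s.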

Compound 3, apparent permeability: 265 nm/s
Compound 3: middle estimate off by 1.5-fold (0.18 log units), on the high side; the measured number falls inside the stated range.
By their numbers in this assay, from the lowest: compound 2; then compound 3; then compound 1.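

In this assay the low reading of compound 2 does not hold for every piperazin-1-yl on this aromatic carbon: 4-cyclopropylpiperazin-1-yl in place of 3,5-dimethylpiperazin-1-yl gives a 6.8-fold higher number from compound 2 to compound 3 (0.83 log units; beyond the scatter) and so takes the series most of the way back towards compound 1. The group on the ring amine nitrogen also matters on its own, a change the earlier pair did not isolate: cyclopropyl in place of oxetan-3-yl gives a 2.7-fold lower number from compound 1 to compound 3 (0.44 log units; beyond the scatter) with the rest of the structure unchanged, and this step too is beyond the scatter. Nothing measured here speaks to why these numbers differ.

Going by these compounds, compound 2 and compound 3 differ both in the methyl groups on the ring carbons and in the group on the ring nitrogen, so the share of each in that step stays open. Also open, on these data alone, is how a morpholin-4-yl on the same aromatic carbon, or a piperazin-1-yl carrying a 2-hydroxyethyl or an acetyl group on its ring nitrogen, would read in this assay against these three compounds.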